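Bromo to methyl at the limit of the assay

A few compounds are considered here, and "the series" means these few. Any claim that something is new, unique, unknown or untested is made for them only; others in the source may bear on it.

Compound 3 `CCN1C(=O)C(O)(Cc2nnn[nH]2)c2cc(Br)ccc21` has no numerical reading in a functional assay on MDA-MB-231 cells (Homo sapiens) for antiproliferative activity, read by MTT assay, with a stated time of 48 h; a lower number here means a stronger inhibitor, a higher number a weaker inhibitor. Compound 3 reads > 100000 nM, which is a limit of the assay. Compound 1 `CCN1C(=O)C(O)(Cc2nnn[nH]2)c2ccccc21`, with hydrogen in place of the halogen, reads > 100000 nM, which is also a limit. Going by the values given here, compound 2 `CCN1C(=O)C(O)(Cc2nnn[nH]2)c2cc(Cl)ccc21`, the chloro analogue, gives 84900 nM, the only true number so far. The picture across these three is the limit of > 100000 nM in this assay, at which 2 of the 3 values shown sit.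

The next compound, compound 4 `CCN1C(=O)C(O)(Cc2nnn[nH]2)c2cc(C)ccc21`, has methyl in place of bromo on an aromatic carbon. Among the compounds with values here, three measured steps bear on this change. Chloro in place of hydrogen gave an at least 1.1-fold lower number from compound 1 to compound 2 (0.07 log units; that floor lies within the scatter). Bromo in place of hydrogen gave a step that the two limits leave unreadable from compound 1 to compound 3. Bromo in place of chloro gave an at least 1.1-fold higher number from compound 2 to compound 3 (0.07 log units; that floor lies within the scatter). None of these steps is shown to exceed the scatter, and no methyl compound has yet been measured. Given an at least 1.1-fold higher number from compound 2 to compound 3 (0.07 log units; that floor lies within the scatter), no step beyond the scatter is expected in this assay, in either direction. The expected change is an at least 1.0-fold lower number from compound 3 to compound 4 (0.02 log units; that floor lies within the scatter). Another reading at the limit would be no surprise. For compound 4 the estimated value is 95000 nM, with an expected range of 50000 nM to 180000 nM.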

Compound 4, half-maximal inhibitory concentration: > 100000 nM
Compound 4 gave a limit, no number; the forecaster's own chance of this, stated with the estimate: 60%; at least 1.0-fold (0.02 log units) between middle value and limit.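

Methyl now joins hydrogen and bromo as a group at this position that gives no number in this assay, so the limit is reached with a carbon group as well as with a halogen, and compound 2, with chloro, is the one compound that goes against this. The only new step that can be read is an at least 1.1-fold higher number from compound 2 to compound 4 (0.07 log units; that floor lies within the scatter), which leaves chloro and methyl at this position not shown to differ. The steps to compound 4 from compound 3 and from compound 1 cannot be read, as both ends of each are limits, and the series now gathers at one edge of the measurable range: the limit of > 100000 nM in this assay, at which 3 of the 4 values shown sit.

From the compounds shown here alone, whether any group at this position can bring a reading clear of the limit stays open, as compound 2 alone carries a true number and no other group has been set against it. Going by these compounds, what an amine, a carboxylic acid or a methoxy group would read here remains unknown, as does the effect on the reading of a longer chain in place of the ethyl group of the shared core.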